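Cytotoxicity notes: compound 4 as an extension of compound 3

The source may hold more compounds than are shown below. What is called first, only, known or untested is meant among the compounds shown, and "the series" means these compounds.

Compound 1 `COc1cccc2cc(-c3ccccc3)c(O)nc12` and compound 2 `COc1ccc2cc(-c3ccccc3)c(O)nc2c1` share the core; compound 3 `COc1ccc(-c2cc3c(OC)cc(OC)cc3n(C)c2=O)cc1` carries the same core with further substitution. In a functional assay on PC-3 cells (Homo sapiens) for cytotoxicity, read by colorimetric assay and MTT assay (on this read-out higher numbers stand for weaker inhibition and lower numbers for stronger inhibition), compound 1 gives 10000 nM. Compound 2 gives 10000 nM in this assay. Compound 3 gives 10000 nM in this assay, level with compound 1 and compound 2 at the digits shown, so no order among the three can be read. Compound 4 `CCN(CC)C(=O)Cn1c(=O)c(-c2ccc(OC)cc2)cc2c(OC)cc(OC)cc21` remains unmeasured. It differs from compound 3 by diethylcarbamoyl in place of hydrogen on a saturated chain carbon bound to an aromatic nitrogen. For the measured compounds named here, the measured compounds contain no step that speaks to such a change; all three rest at one value. The expected step is no change at the digits printed from compound 3 to compound 4 (within the scatter), none beyond the scatter. Compound 4 is therefore estimated at 10000 nM, in the range 4000 nM to 30000 nM.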

Compound 4, half-maximal inhibitory concentration: 10000 nM
Compound 4: middle estimate and measured number agree at the digits printed, within the range that was stated.
By their numbers in this assay, from the lowest: compounds 1, 2, 3 and 4 (each within the scatter of the next).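

For the compounds shown here, the earlier compounds offered no step between them; this pair gives the only reading at this position. In this assay, diethylcarbamoyl in place of hydrogen on a saturated chain carbon bound to an aromatic nitrogen gives no change at the digits printed from compound 3 to compound 4 (within the scatter), so this change of 7 heavy atoms leaves the value unmoved at the digits printed. No measurement shown bears on the reason for this result.

Open, from the compounds shown here alone, is whether a free amine or a carboxylic acid at this place, or a longer chain, would give a value apart from that of compound 4 at 10000 nM. Also open, going by these compounds, is whether any change to the shared core would separate the series in this assay at all.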